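The compounds below may be only part of what the source reports. "The series", "measured", "known", "first", "only" and "open" are said of these compounds alone.

In a functional assay on HT-29 cells (Homo sapiens) for antiproliferative activity, read by sulforhodamine B assay, with a stated time of 48 h (a lower number here means a stronger inhibitor, a higher number a weaker inhibitor), compound 1 (`CCCCc1ccc(NS(=O)(=O)c2ccc(N3CCNC3=O)cc2)cc1`) gives 610 nM. Compound 2 (`CCCCCCCc1ccc(NS(=O)(=O)c2ccc(N3CCNC3=O)cc2)cc1`) gives > 1000 nM, which is a limit of the assay and not a number. Compound 2 therefore has no exact place on the scale. Compound 3 (`CCCCOc1ccc(NS(=O)(=O)c2ccc(N3CCNC3=O)cc2)cc1`) departs from it through one change, butoxy in place of heptyl on an aromatic carbon. Among the compounds with values here, the only measured step bearing on this is an at least 1.6-fold higher number from compound 1 to compound 2 (0.21 log units; that floor lies within the scatter), which lengthens the chain of compound 1. Within the data shown here, the shorter chain of compound 1, at 610 nM, is the only guide, and it points to a modest move toward a lower number in this assay, though that move may not clear the scatter. The expected step is an at least 1.6-fold lower number from compound 2 to compound 3 (0.22 log units; that floor lies within the scatter). Compound 3 is estimated at 600 nM, with an expected range from 220 nM to 1500 nM.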

Compound 3, half-maximal inhibitory concentration: 630 nM
Estimate against measurement, compound 3: 1.1-fold (0.02 log units) below, and the stated range covers the measured number.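

Within the data shown here, what the earlier compounds could not show is that butoxy in place of butyl on this aromatic carbon can be read directly in this assay and gives a 1.0-fold higher number from compound 1 to compound 3 (0.01 log units; within the scatter) and the two groups cannot be told apart here. The change from heptyl gives an at least 1.5-fold lower number from compound 2 to compound 3 (0.20 log units; that floor lies within the scatter) and so adds only a floor that does not clear the scatter. Going by these compounds, compound 2 stands at a limit of the assay and not at a number, so the true size of that step stays unknown: the limit of > 1000 nM in this assay, at which 1 of the 3 values shown sits.

The compounds shown leave open how a longer chain joined through oxygen, such as hexyloxy, would read at this aromatic carbon. They also leave open whether an amine or a carboxylic acid there would depart from the values of the butyl and butoxy compounds.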